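Swapping a Carboxypyrrolidine for a Piperidine

This account rests on a few compounds, and the source may have more. Where it says the series, first, only, none or still open, it means among the compounds named here.

Measured compounds:
- compound 1, `Cc1nn([C@H](C)c2ccc(Cl)cc2Cl)c2nc(N3CC[C@H](N4CCCCCC4)[C@H](C)C3)cnc12`: 195 nM
- compound 2, `Cc1nn([C@H](C)c2ccc(Cl)cc2Cl)c2nc(N3CC[C@H](N4CCC[C@H]4CCC(N)=O)[C@H](C)C3)cnc12`: 355 nM
- compound 3, `Cc1nn([C@H](C)c2ccc(Cl)cc2Cl)c2nc(N3CC[C@H](N4CCC[C@H]4C(=O)O)[C@H](C)C3)cnc12`: "not determined" (no result reported)

All three share a core and differ only in the group on a saturated ring carbon. For the measured compounds named here, in an assay on CCRF-CEM cells for antagonist activity at C-C chemokine receptor type 4 (Homo sapiens), read by CellTiter-Glo, with stated times of 30 min and 60 min, in the presence of a further agent that is not named here (a lower number here means a stronger inhibitor, a higher number a weaker inhibitor), compound 1 gives 195 nM and compound 2 gives 355 nM; the one measured step, a 1.8-fold higher number from compound 1 to compound 2 (0.26 log units; within the scatter), shows that replacing azepan-1-yl with 2-(2-carbamoylethyl)pyrrolidin-1-yl changes little. For compound 3 the entry in this assay reads "not determined" (no result reported), so it stands without a value.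

The step to compound 4, `Cc1nn([C@H](C)c2ccc(Cl)cc2Cl)c2nc(N3CC[C@H](N4CCCCC4)[C@H](C)C3)cnc12`, is piperidin-1-yl in place of 2-carboxypyrrolidin-1-yl on a saturated ring carbon. Going by the values given here, because compound 3 has no value, the only anchors are compound 1 with 195 nM and compound 2 with 355 nM, both carrying a saturated nitrogen ring at the same place. Piperidin-1-yl is a ring of the same kind as azepan-1-yl in compound 1, so a number near that of compound 1 is expected, with no step beyond the scatter. The estimate for compound 4 in this assay is 220 nM, within 80 nM to 600 nM.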

Compound 4, half-maximal inhibitory concentration: 361 nM
Estimate against measurement, compound 4: 1.6-fold (0.22 log units) below; the measured number falls inside the stated range.
By their numbers in this assay, from the lowest: compounds 1, 2 and 4 (each within the scatter of the next).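

In this assay a third ring group now sits on this saturated ring carbon, and a 1.9-fold higher number from compound 1 to compound 4 (0.27 log units; within the scatter) and a 1.0-fold higher number from compound 2 to compound 4 (0.01 log units; within the scatter) are both small steps. Piperidin-1-yl, azepan-1-yl and 2-(2-carbamoylethyl)pyrrolidin-1-yl therefore cannot be told apart here: across compound 1, compound 2 and compound 4, neither the change of ring nor the carbamoylethyl side chain moves the number beyond the scatter. Compound 3 has no value, so the step from compound 3 to compound 4 cannot be read, and the swap of 2-carboxypyrrolidin-1-yl for piperidin-1-yl stays without a size.

Still open, as far as these compounds go, is how a morpholine ring or an open-chain amine would read at this place, and whether a carboxylic acid here sets a compound apart from the others. No supporting data bear on why these groups read alike.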